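The source may report more compounds than this note shows. Statements on the series, on what has been measured and on what is new or still open speak of the compounds shown alone.

Of the compounds shown here, three have been measured in a functional assay for antagonist activity at 5-hydroxytryptamine receptor 4 (Rattus norvegicus); on this read-out higher numbers stand for higher potency (the scale is a negative logarithm) and lower numbers for lower potency. Compound 1 `COc1ccc(COc2cc(N)c(Cl)cc2C(=O)CCCCN2CCCCC2)cc1` gives 8.4. Compound 2 `COc1ccc(CCOc2cc(N)c(Cl)cc2C(=O)CCCCN2CCCCC2)cc1OC` gives 6.8. Compound 3 `COc1cc(COc2cc(N)c(Cl)cc2C(=O)CCCCN2CCC(c3ccccc3)CC2)cc(OC)c1` gives 7.7, which puts compound 3 second among the three, between the others. Within the data shown here, the only measured step that changes a single part of the molecule, a number 1.60 log units lower from compound 1 to compound 2 (beyond the scatter), concerns the group on the saturated chain carbon bound to an oxygen on the aromatic ring, a part of the molecule far from where compound 4 differs. Compound 1 and compound 3 differ in two places at once, so their two values can only be noted side by side and not read as one step.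

Compound 4 `COc1cc(COc2cc(N)c(Cl)cc2C(=O)CCCCN2CCC(NC(N)=O)CC2)cc(OC)c1` differs from compound 3 in one place: ureido in place of phenyl on a saturated ring carbon, so that 4-phenylpiperidin-1-yl becomes 4-ureidopiperidin-1-yl. Among the measured compounds shown here, none of the measured steps touches this part of the molecule, so there is no direct guide for this change in this assay. The expectation is therefore loose and leans toward a modest loss, so that compound 4 is estimated at 7.2, within a range from 6.2 to 8.2. That estimate corresponds to an expected step of a number 0.50 log units lower from compound 3 to compound 4 (beyond the scatter).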

Compound 4, negative logarithm of the antagonist equilibrium constant: 8.5
The estimate for compound 4 lay 1.30 log units below the measured number; the whole stated range lies below it.
By their numbers in this assay, from the lowest: compound 2; then compound 3; then compounds 1 and 4 (each within the scatter of the next).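

In this assay, among these compounds, ureido in place of phenyl on a saturated ring carbon of the six-membered non-aromatic ring gives a number 0.80 log units higher from compound 3 to compound 4 (beyond the scatter), the first measured step at this position. This pair shows that the aromatic ring of phenyl is not required here for high potency: a group without a ring, with fewer heavy atoms and with 2 hydrogen-bond donors where phenyl has none, gives the higher number of the two. No measurement shown accounts for the direction or size of this step, so it stands as an observation about one pair.

A single pair cannot separate the contributions of the parts of the ureido group, and a plain amine, an acetamide or a carboxylic acid on the same ring carbon would help show whether its nitrogens, its carbonyl or simply the absence of phenyl goes with the higher number. Going by these compounds, it also remains open whether the same change would give a step of similar size with a different group on the oxygen of the shared core, such as 4-methoxybenzyl.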